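Positional shift of the amine in the side-chain amide

The compounds below may be only part of what the source reports. "The series", "measured", "known", "first", "only" and "open" are said of these compounds alone.

Measured compounds:
compound 1 `CC(C)[C@H](NC(=O)CCN(C)C)c1cccc(F)c1N1CCN(C(=O)[C@@H]2CN(C(C)C)C[C@H]2c2cc(F)cc(F)c2)CC1`: 7800 nM
compound 2 `Cc1ccc(N2CCN(C(=O)[C@@H]3CN(C4CCOCC4)C[C@H]3c3ccc(Cl)cc3)CC2)c([C@@H](NC(=O)CCN)C(C)C)c1`: 2.2 nM

In an assay on HEK293 cells for displacement of a labelled ligand from Melanocortin receptor 4 (Homo sapiens) (a higher number here means a weaker inhibitor, a lower number a stronger inhibitor), compound 1 gives 7800 nM, while compound 2 gives 2.2 nM, the lowest of the two numbers; the gap between the two compounds lies far beyond the scatter. Within the data shown here, no single-point step between the two measured compounds exists, as they differ in several places at once, so the series gives no direct guide to the change now at hand.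

Compound 3 `Cc1ccc(N2CCN(C(=O)[C@@H]3CN(C4CCOCC4)C[C@H]3c3ccc(Cl)cc3)CC2)c([C@@H](NC(=O)[C@H](C)N)C(C)C)c1` is not yet measured in this assay. It differs from compound 2 as follows: 1-aminoethyl in place of 2-aminoethyl on a carbonyl carbon The two compounds have the same atoms joined differently, the amine moving along the aminoethyl group attached to the carbonyl carbon.

Nothing measured here bears on such a shift, so the expected step from compound 2 to compound 3 is modest and of uncertain direction, a 1.4-fold higher number from compound 2 to compound 3 (0.13 log units; within the scatter), most likely within or near the scatter. Compound 3 is therefore estimated at 3 nM in this assay, with a range from 0.7 nM to 15 nM.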

Compound 3, inhibition constant: 1 nM
Beside the measured number, compound 3's estimate is 3.0-fold (0.48 log units) above it, within the range that was stated.
By their numbers in this assay, from the lowest: compound 3; then compound 2; then compound 1.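

In this assay, moving the amine along the aminoethyl group on the carbonyl carbon gives a 2.2-fold lower number from compound 2 to compound 3 (0.34 log units; beyond the scatter). This is a reading of one change at one place, which compound 1 and compound 2, differing in several places at once, could not give, and it shows that this position accepts 1-aminoethyl in place of 2-aminoethyl with a modest gain, while the heavy-atom, donor and acceptor counts stay the same and one defined stereocentre enters. No supporting measurement is available to explain the step.

Still open, on these data alone, is how the other configuration at the new stereocentre reads, and how an aminomethyl group, a longer 3-aminopropyl chain or a carboxylic acid in place of the amine would read on this carbonyl carbon. Also open, as far as these compounds go, is whether the same shift gives a step of similar size on the core of compound 1, where the amine is a dimethylamino group and the other substituents differ.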